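Swapping chloromethyl for cyclopropyl on a carbonyl carbon

The source may report more compounds than this note shows. Statements on the series, on what has been measured and on what is new or still open speak of the compounds shown alone.

Of the compounds shown here, three sharing one core have been tested in a functional assay on K562 cells (Homo sapiens) for cytotoxicity, read by MTT assay; a lower number here means a stronger inhibitor, a higher number a weaker inhibitor. Compound 1 `COc1ccc(/C=C/C(=O)c2ccc(OC)c3c2OC(C)(C)C=C3)cc1OCCO` gives 8750 nM, compound 2 `CCCCC(=O)Oc1cc(/C=C/C(=O)c2ccc(OC)c3c2OC(C)(C)C=C3)ccc1OC` gives 240 nM, and compound 3 `COc1ccc(/C=C/C(=O)c2ccc(OC)c3c2OC(C)(C)C=C3)cc1OC(=O)CCl` gives 400 nM. Compound 3 therefore stands close to compound 2 and far from compound 1.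

The next compound, compound 4 `COc1ccc(/C=C/C(=O)c2ccc(OC)c3c2OC(C)(C)C=C3)cc1OC(=O)C1CC1`, has cyclopropyl in place of chloromethyl on a carbonyl carbon. The carbonyl group stays on the same oxygen, and only the group hanging from it changes.

Two kinds of measured step bear on this. Replacing 2-hydroxyethyl on that oxygen brought large steps: a 36-fold lower number from compound 1 to compound 2 (1.56 log units; beyond the scatter) with butylcarbonyl, and a 22-fold lower number from compound 1 to compound 3 (1.34 log units; beyond the scatter) with (chloromethyl)carbonyl. Compound 4 does not undo that replacement, so a step of this size is not expected. The closer parallel is the exchange of one group for another on the carbonyl side, and there the measured step was small: a 1.7-fold higher number from compound 2 to compound 3 (0.22 log units; within the scatter). Going by the values given here, this is a single comparison, and no compound with a cyclopropyl group has been measured yet.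

The estimated step is a 1.3-fold lower number from compound 3 to compound 4 (0.12 log units; within the scatter), so no change beyond the scatter is expected. Compound 4 is expected at 300 nM, with an estimated range of 120 nM to 800 nM.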

Compound 4, half-maximal inhibitory concentration: 410 nM
Estimate against measurement, compound 4: 1.4-fold (0.14 log units) below, and the stated range covers the measured number.
By their numbers in this assay, from the lowest: compounds 2, 3 and 4 (each within the scatter of the next); then compound 1.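

In this assay, exchanging chloromethyl for cyclopropyl on this carbonyl carbon gives a 1.0-fold higher number from compound 3 to compound 4 (0.01 log units; within the scatter), and exchanging butyl for cyclopropyl gives a 1.7-fold higher number from compound 2 to compound 4 (0.23 log units; within the scatter), so a group holding chlorine, an open chain and a three-membered ring of carbon all read alike at this place. The large difference from the 2-hydroxyethyl group also holds with the ring in place, at a 21-fold lower number from compound 1 to compound 4 (1.33 log units; beyond the scatter), which extends what was seen with the two earlier carbonyl groups to a third, differently shaped one. Nothing measured here accounts for why these three groups read alike or why the 2-hydroxyethyl compound stands so far from them.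

On these data alone, it remains open whether this sameness would last with an amine, a carboxylic acid, a phenyl ring or a much longer chain on the carbonyl carbon, as these three groups cover only a small part of what could sit there. As far as these compounds go, it is also open whether the carbonyl itself matters, which a plain ethyl group on the same oxygen could help to settle when set beside the 2-hydroxyethyl compound.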